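The source may hold more compounds than are shown below. What is called first, only, known or untested is meant among the compounds shown, and "the series" means these compounds.

Measured in a functional assay on SKHep cells (Homo sapiens) for antiproliferative activity, read by MTT assay, with a stated time of 12 h; a higher number here means a weaker inhibitor, a lower number a stronger inhibitor:

compound 1 `COc1cc(OC)c2c(=O)cc(/C=C/c3ccc([N+](=O)[O-])cc3)oc2c1`: 22000 nM
compound 2 `COc1cc(OC)c2c(=O)cc(/C=C/c3ccc(OCC4CC4)cc3)oc2c1`: 22100 nM
compound 3 `COc1cc(OC)c2c(=O)cc(/C=C/c3ccccc3)oc2c1`: 26000 nM

All three compounds share the same core and differ only in the group on the aromatic carbon of the phenyl ring. Compound 3, the unsubstituted phenyl, is the reference point here; the steps leading to it, a 1.2-fold higher number from compound 1 to compound 3 (0.07 log units; within the scatter) and a 1.2-fold higher number from compound 2 to compound 3 (0.07 log units; within the scatter), are both within the scatter, as is a 1.0-fold higher number from compound 1 to compound 2 (0.00 log units; within the scatter), so the three numbers cannot be told apart in this assay.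

Compound 4 `COc1cc(OC)c2c(=O)cc(/C=C/c3ccc(Cl)cc3)oc2c1` differs from compound 3 by chloro in place of hydrogen on an aromatic carbon. Among the measured compounds shown here, the steps that bear on this change are the ones that swap the group at that same aromatic carbon: nitro and cyclopropylmethoxy against hydrogen. Neither of them moved the number beyond the scatter. The expectation for chloro at the same place is therefore a step of no size beyond the scatter, in no particular direction, with the estimate a 1.1-fold lower number from compound 3 to compound 4 (0.03 log units; within the scatter). On that basis compound 4 is expected at 24000 nM, with a range from 12000 nM to 48000 nM in this assay.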

Compound 4, half-maximal inhibitory concentration: 26900 nM
The estimate for compound 4 lay 1.1-fold (0.05 log units) below the measured number; the measured number falls inside the stated range.
By their numbers in this assay, from the lowest: compounds 1, 2, 3 and 4 (each within the scatter of the next).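

In this assay, chloro in place of hydrogen on the phenyl ring gives a 1.0-fold higher number from compound 3 to compound 4 (0.01 log units; within the scatter), so this change adds a single chlorine atom with no step beyond the scatter. Against the other substituted compounds, the swaps give a 1.2-fold higher number from compound 2 to compound 4 (0.09 log units; within the scatter) and a 1.2-fold higher number from compound 1 to compound 4 (0.09 log units; within the scatter), so hydrogen, nitro, cyclopropylmethoxy and chloro at this aromatic carbon now form a set of four that cannot be told apart in this assay, a flat stretch that extends the earlier three-compound picture to a fourth group. No measurement is at hand that bears on why the number stays put across these groups.

Still open, as far as these compounds go, is whether an amine or a carboxylic acid at this same carbon would move the number beyond the scatter. Also open, from the compounds shown here alone, is whether chloro at another carbon of the phenyl ring, or a change on the shared core, would do so.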